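This account rests on a few compounds, and the source may have more. Where it says the series, first, only, none or still open, it means among the compounds named here.

Measured so far in this study:

Compound 1 `COc1ccc(/C=C/C2CC=CC(=O)O2)cc1`: 20.6 uM
Compound 2 `COc1ccc(/C=C/C2CC=CC(=O)O2)c(OC)c1`: 4.6 uM
Compound 3 `COc1ccc(/C=C/C2CC=CC(=O)N2)cc1OC`: > 964 uM

All three numbers come from a functional assay on U-251 cells (Homo sapiens) for inhibition, read by sulforhodamine B assay, with a stated time of 48 h; on this read-out lower numbers stand for stronger inhibition of growth and higher numbers for weaker inhibition of growth. Compound 1 and compound 2 share a core and differ by methoxy in place of hydrogen on an aromatic carbon; that step gave a 4.5-fold lower number from compound 1 to compound 2 (0.65 log units; beyond the scatter). Compound 3 carries a different core, and the difference between the two cores is not broken down here. For compound 3 the result is only a limit of the assay, not a number, as shown by the limit of > 964 uM in this assay, at which 1 of the 3 values shown sits.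

Compound 4 `COc1cc(OC)c(OC)cc1/C=C/C1CC=CC(=O)N1` has not been measured. It differs from compound 3 by methoxy in place of hydrogen on an aromatic carbon. Here the entering methoxy is also para to a methoxy group, which was not so in compound 2, so this is the same kind of change, not the same one. The expected step of an at least 2.4-fold lower number from compound 3 to compound 4 (0.38 log units; beyond the scatter) rests on the earlier step of a 4.5-fold lower number from compound 1 to compound 2 (0.65 log units; beyond the scatter). Compound 4 is therefore estimated at 400 uM, between 80 uM and 2000 uM.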

Compound 4, concentration for growth inhibition (reported as GI): > 864 uM
Compound 4: only a limit was reported; the forecaster's own chance of this, stated with the estimate: 55%; at least 2.1-fold (0.33 log units) between middle value and limit.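

Compound 3 and compound 4 each gave only a limit of the assay, not a number, so the step between them cannot be read. Going by these compounds, whether methoxy changes growth inhibition on this core stays open.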